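Branching a Phenoxy Chain in a Fatty Acid Receptor Series

The compounds below may be only part of what the source reports. "The series", "measured", "known", "first", "only" and "open" are said of these compounds alone.

Compound 1 `O=C(O)COc1ccc(NC(=O)COc2ccccc2)cc1F` is the parent of this small set. In a functional assay on CHO cells for agonist activity at Free fatty acid receptor 1 (Homo sapiens), read by FLIPR, tested at 100 nM (a higher number here means a stronger effect of the compound at the concentration tested, a lower number a weaker effect), compound 1 gives 29.8%. Compound 2 `CC(Oc1ccccc1)C(=O)Nc1ccc(OCC(=O)O)c(F)c1` carries methyl in place of hydrogen on a saturated chain carbon bound to a carbonyl carbon and an oxygen on an aromatic ring; this brings a number 5.9 percentage points higher from compound 1 to compound 2 (within the scatter), and compound 2 gives 35.7%. Compound 3 `CCc1ccc(OCC(=O)Nc2ccc(OCC(=O)O)c(F)c2)cc1` differs from compound 1 by ethyl in place of hydrogen on an aromatic carbon; the step is a number 15.2 percentage points lower from compound 1 to compound 3 (beyond the scatter), and compound 3 gives 14.6%, the lowest of the three numbers.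

Compound 4 `CC(C)c1ccc(OCC(=O)Nc2ccc(OCC(=O)O)c(F)c2)cc1` has not yet been measured. It differs from compound 3 by methyl in place of hydrogen on a saturated chain carbon bound to an aromatic carbon and a saturated chain carbon. Going by the values given here, this is the same kind of change as the one from compound 1 to compound 2, though there the methyl entered on a saturated chain carbon bound to a carbonyl carbon and an oxygen on an aromatic ring, whereas here it enters on a saturated chain carbon bound to an aromatic carbon and a saturated chain carbon. Because the earlier step was a number 5.9 percentage points higher from compound 1 to compound 2 (within the scatter), a step of similar small size is expected here, a number 3.4 percentage points higher from compound 3 to compound 4 (within the scatter). Compound 4 is therefore estimated at 18% in this assay, with a likely range from 8% to 30%.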

Compound 4, a percentage reported as activity, at one concentration (the size of the read-out at that concentration, not a potency): 11.8%
Estimate against measurement, compound 4: 6.2 percentage points above; the measured number falls inside the stated range.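

The step on this core is a number 2.8 percentage points lower from compound 3 to compound 4 (within the scatter) in this assay, so turning ethyl into isopropyl produces no change that can be told from the scatter. Set beside the earlier methyl step, this result gives no sign that the change behaves differently on the two cores: the same change on two cores in this assay, a number 5.9 percentage points higher (within the scatter) from compound 1 to compound 2 and a number 2.8 percentage points lower (within the scatter) from compound 3 to compound 4, 8.7 percentage points apart, within the scatter of two such steps. This does not show that the methyl has no effect, nor that it would behave alike on other cores, since two steps this small could hide a real difference; the clear change is a number 18 percentage points lower from compound 1 to compound 4 (beyond the scatter) and belongs to adding the whole isopropyl group to the core of compound 1.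

Still open, as far as these compounds go, is what a larger group such as tert-butyl, or a different one such as an amine, would do where compound 4 carries its isopropyl. Also open, from the compounds shown here alone, is whether the methyl on the chain carbon bound to the carbonyl carbon would give a similar result in compound 3 or compound 4.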